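Sulfonate ureas with a chloropropyl chain: one-chain truncation

The source may report more compounds than this note shows. Statements on the series, on what has been measured and on what is new or still open speak of the compounds shown alone.

Measured so far:
compound 1 `CCc1ccccc1OS(=O)(=O)c1cccc(NC(=O)NCCCCl)c1` — 25000 nM
compound 2 `Cc1ccccc1OS(=O)(=O)c1ccc(NC(=O)NCCCCl)cc1` — 27000 nM
compound 3 `CCNC(=O)Nc1cccc(S(=O)(=O)Oc2ccccc2CC)c1` — 31000 nM

All three were tested in a functional assay on MCF7 cells (Homo sapiens) for cytotoxicity, read by sulforhodamine B assay, with a stated time of 48 h; on this read-out lower numbers stand for stronger inhibition and higher numbers for weaker inhibition. Compound 1 gives 25000 nM and compound 3 gives 31000 nM in this assay, a step of a 1.2-fold higher number from compound 1 to compound 3 (0.09 log units; within the scatter) on the change (hydrogen in place of chloromethyl on a saturated chain carbon, two bonds along the chain from an amide-type nitrogen). Compound 2 sits among them in this assay at 27000 nM; how its core differs from the core of compound 1 is not broken down here.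

Compound 4 `CCNC(=O)Nc1ccc(S(=O)(=O)Oc2ccccc2C)cc1` has not been measured. It stands to compound 2 as compound 3 stands to compound 1, carrying the same change, (hydrogen in place of chloromethyl on a saturated chain carbon, two bonds along the chain from an amide-type nitrogen), at a place described in the same words. Among the measured compounds shown here, because the one measured instance gave a 1.2-fold higher number from compound 1 to compound 3 (0.09 log units; within the scatter), the step from compound 2 to compound 4 is expected to be about as small, a 1.1-fold higher number from compound 2 to compound 4 (0.05 log units; within the scatter). Compound 4 is therefore estimated at 30000 nM in this assay, with a range of 15000 nM to 60000 nM.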

Compound 4, half-maximal inhibitory concentration: 4500 nM
For compound 4 the middle estimate is 6.7-fold (0.82 log units) above the measured one; the measured number lies below the stated range.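

Replacing 3-chloropropyl with ethyl gives a 6.0-fold lower number from compound 2 to compound 4 (0.78 log units; beyond the scatter) in this assay. The effect of this change therefore depends on the core across these two pairs: the same change on two cores in this assay, a 1.2-fold higher number (0.09 log units; within the scatter) from compound 1 to compound 3 and a 6.0-fold lower number (0.78 log units; beyond the scatter) from compound 2 to compound 4, 7.4-fold (0.87 log units) apart, beyond the scatter of two such steps The step measured on one core cannot be carried over to the other, but these pairs do not show which feature of the cores sets the gap, and they give no rule for any further core.

Going by these compounds, it remains open how either core responds to a 2-chloroethyl chain, a longer chain or a propyl chain ending in an amine instead of chlorine. On these data alone, a carboxylic acid at the end of the chain is equally open.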